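This account rests on a few compounds, and the source may have more. Where it says the series, first, only, none or still open, it means among the compounds named here.

Of the compounds shown here, three have so far been measured in a functional assay on MDA-MB-231 cells (Homo sapiens) for cytotoxicity, read by sulforhodamine B assay, tested at 10 uM; on this read-out higher numbers stand for more inhibition at the one concentration tested (going by the name of the read-out) and lower numbers for less inhibition. Compound 1 `CC(=O)OC[C@H]1O[C@@H](n2cc(-c3cn(Cc4ccc(C(C)C)cc4)nn3)c(=O)[nH]c2=O)C[C@@H]1OC(C)=O` gives 98.1%, compound 3 `CC(C)(C)c1ccc(-c2cc(-c3cn([C@H]4C[C@H](O)[C@@H](CO)O4)c(=O)[nH]c3=O)on2)cc1` gives 102%, and compound 2 `CC(=O)OC[C@H]1O[C@@H](n2cc(-c3cc(-c4ccc(C(C)(C)C)cc4)no3)c(=O)[nH]c2=O)C[C@@H]1OC(C)=O` gives 69.3%, which stands lowest of the three numbers: its nearest neighbour is compound 1, whose number lies higher by a margin beyond the scatter, and compound 3 lies further off, also beyond the scatter.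

Compound 4 `CC(=O)OC[C@H]1O[C@@H](n2cc(-c3cc(C)no3)c(=O)[nH]c2=O)C[C@@H]1OC(C)=O` has not yet been measured in this assay. It differs from compound 2 in a single place: methyl in place of 4-(tert-butyl)phenyl on an aromatic carbon Because compound 2 already gives 69.3% and the change removes the 4-(tert-butyl)phenyl group in favour of methyl, the step to compound 4 is expected to be downward and larger than the scatter. Compound 4 is estimated at 35%, with a range from 10% to 65%. Within the data shown here, this estimate means a number 34.3 percentage points lower from compound 2 to compound 4 (beyond the scatter), an expected fall beyond the scatter, though no measured step confirms it.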

Compound 4, a percentage reported as inhibition, at one concentration (the size of the read-out at that concentration, not a potency): 106%
The estimate for compound 4 lay 71 percentage points below the measured number; measured number above the stated range.
By their numbers in this assay, from the lowest: compound 2; then compounds 1, 3 and 4 (each within the scatter of the next).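

In this assay, putting methyl in place of 4-(tert-butyl)phenyl on the aromatic carbon next to the ring nitrogen gives a number 36.7 percentage points higher from compound 2 to compound 4 (beyond the scatter), a large step and the first one that can be read at this position. It shows that the 4-(tert-butyl)phenyl group, with its six-membered aromatic ring of carbon only, is not required at this position for a high read-out on this pair, since the much smaller methyl gives the higher number. Nothing available explains the rise.

The pair leaves open how a phenyl without the tert-butyl group, a longer alkyl chain, an amine or a carboxylic acid would read at this carbon. On these data alone, with a single tested concentration, the potency of either compound also remains open.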